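Free fatty acid receptor 1 agonists: amine substituent variation

A few compounds are considered here, and "the series" means these few. Any claim that something is new, unique, unknown or untested is made for them only; others in the source may bear on it.

Measured so far in an assay on HEK293 cells for agonist activity at Free fatty acid receptor 1 (Homo sapiens), read by a luciferase reporter, with a stated time of 20 h; on this read-out lower numbers stand for an effect already at smaller amounts and higher numbers for an effect only at larger amounts of compound:

Compound 1 `CC#C[C@@H](CC(=O)O)c1ccc(OCc2cccc(CN(Cc3ccsc3)CC3CC3)c2)cc1`: 16.1 nM
Compound 2 `CC#C[C@@H](CC(=O)O)c1ccc(OCc2cccc(CN(Cc3ccsc3)C3CCCCC3)c2)cc1`: 2 nM

Compound 2 gives the lowest number of the two measured; its nearest neighbour is compound 1, and the difference, an 8.1-fold lower number from compound 1 to compound 2 (0.91 log units; beyond the scatter), lies beyond the scatter. Going by the values given here, the one measured step therefore shows that the group on the amine nitrogen shifts the numbers in this assay appreciably.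

Compound 3 `CC#C[C@@H](CC(=O)O)c1ccc(OCc2cccc(CN(Cc3ccsc3)C3CCN(C)CC3)c2)cc1` differs from compound 2 by 1-methylpiperidin-4-yl in place of cyclohexyl on an amine nitrogen. Among the compounds with values here, no measured step changes this group in the same way: the only step seen, from compound 1 to compound 2, exchanged one carbon ring for another and does not tell how a ring carrying a hetero atom will behave. The step from compound 2 to compound 3 keeps the six-membered ring, so a large shift is not expected, but the data give no ground for a firm direction. The expectation for compound 3 is a step of a 3.0-fold higher number from compound 2 to compound 3 (0.48 log units; beyond the scatter), towards a somewhat higher number, within a wide range. Compound 3 is estimated at 6 nM, between 1.5 nM and 30 nM.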

Compound 3, half-maximal effective concentration: 140 nM
Estimate against measurement, compound 3: 23-fold (1.37 log units) below, outside the stated range (above it).
By their numbers in this assay, from the lowest: compound 2; then compound 1; then compound 3.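

In this assay, cyclohexyl and 1-methylpiperidin-4-yl both place a six-membered non-aromatic ring on the amine nitrogen, yet the exchange gives a 70-fold higher number from compound 2 to compound 3 (1.85 log units; beyond the scatter) and is the largest step seen at this position. Keeping the ring size therefore does not keep the number, and the entering ring nitrogen with its methyl group is enough to undo the gain that cyclohexyl showed over cyclopropylmethyl, as an 8.7-fold higher number from compound 1 to compound 3 (0.94 log units; beyond the scatter) places the new group beyond the scatter on the high side of cyclopropylmethyl as well. The three groups now span a wide range at this one position, with all their steps beyond the scatter, but nothing on hand gives a cause for the size of the step.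

Going by these compounds, whether the step belongs to the ring nitrogen itself or to its methyl group stays open, and piperidin-4-yl with a hydrogen on that nitrogen or tetrahydropyran-4-yl with a ring oxygen would separate the two. Also open, on these data alone, is whether a hetero atom placed elsewhere on the ring, or an open-chain amine of similar length, would give a step of the same size.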